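This account rests on a few compounds, and the source may have more. Where it says the series, first, only, none or still open, it means among the compounds named here.

Measured so far:
compound 1, `CNC(=O)c1ccccc1Oc1nc(Nc2cccc(C)c2)ncc1Br`, in a functional assay on A549 cells (Homo sapiens) for antiproliferative activity, read by MTT assay, with a stated time of 24 h; a lower number here means a stronger inhibitor, a higher number a weaker inhibitor: 6100 nM
compound 2, `CNC(=O)c1ccccc1Oc1nc(Nc2cccc(OC)c2)ncc1Br`, in this assay: 6230 nM

Compound 2 and compound 1 lie within the scatter of each other; the step of a 1.0-fold higher number from compound 1 to compound 2 (0.01 log units; within the scatter) shows that swapping the group on that aromatic carbon left the read-out essentially unchanged. Compound 3, `CNC(=O)c1ccccc1Oc1nc(Nc2cccc(C(C)C)c2)ncc1Br`, has not been measured. It differs from compound 2 in one place: isopropyl in place of methoxy on an aromatic carbon.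

Going by the values given here, only one measured step bears on this change, the one at the same aromatic carbon, a 1.0-fold higher number from compound 1 to compound 2 (0.01 log units; within the scatter), and it lay within the scatter. Among the compounds with values here, no measured pair covers isopropyl, so the expectation rests on that single step. Compound 3 is therefore expected to show a 1.0-fold lower number from compound 2 to compound 3 (0.02 log units; within the scatter), no shift beyond the scatter. Compound 3 is estimated at 6000 nM, within a range from 2500 nM to 15000 nM.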

Compound 3, half-maximal inhibitory concentration: 7140 nM
Compound 3: the middle estimate sits 1.2-fold (0.08 log units) below what was measured; the range from low to high includes it.
By their numbers in this assay, from the lowest: compounds 1, 2 and 3 (each within the scatter of the next).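

In this assay, exchanging the methoxy of compound 2 for isopropyl gives a 1.1-fold higher number from compound 2 to compound 3 (0.06 log units; within the scatter), and exchanging the methyl of compound 1 for isopropyl gives a 1.2-fold higher number from compound 1 to compound 3 (0.07 log units; within the scatter). The earlier pair covered only methyl and methoxy; this result extends the flat read-out at this aromatic carbon to a group of 3 heavy atoms, all carbon, with no hydrogen-bond acceptor, where methoxy has one. No evidence is available to explain why the read-out stays flat across these groups.

The compounds shown leave open whether an amine, a carboxylic acid or a longer chain on this aromatic carbon would move the number beyond the scatter. They also leave open whether the same flat read-out would hold if the shared core were changed elsewhere.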